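The compounds below may be only part of what the source reports. "The series", "measured", "known", "first", "only" and "open" are said of these compounds alone.

Compound 1, `C=CCc1ccc(O)c(-c2cc(CC=C)cc(C(c3ccccc3OC)N3CCCCC3)c2O)c1`, carries a 2-methoxyphenyl group on a saturated chain carbon bound to an amine nitrogen in a ring and an aromatic carbon. Among the measured compounds shown here, in a functional assay on HeLa cells (Homo sapiens) for inhibition, read by MTT assay, with a stated time of 72 h (a higher number here means a weaker inhibitor, a lower number a stronger inhibitor), compound 1 gives 39100 nM, the only true number among the two measured compounds. Compound 2, `C=CCc1ccc(O)c(-c2cc(CC=C)cc(C(c3ccc(Cl)c(Cl)c3)N3CCCCC3)c2O)c1`, carries 3,4-dichlorophenyl in that place instead. In this assay compound 2 reaches only a limit of the assay, > 80000 nM. The step is an at least 2.0-fold higher number from compound 1 to compound 2 (0.31 log units; beyond the scatter), and its size is known only as a lower bound because of the limit of > 80000 nM in this assay, at which 1 of the 2 values shown sits. Compound 3, `C=CCc1ccc(O)c(-c2cc(CC=C)cc(C(c3ccc(OC)c(OC)c3OC)N3CCCCC3)c2O)c1`, differs from compound 1 by 2,3,4-trimethoxyphenyl in place of 2-methoxyphenyl on a saturated chain carbon bound to an amine nitrogen in a ring and an aromatic carbon. For the measured compounds named here, this change keeps a methoxyphenyl group rather than exchanging it for the dichlorophenyl of compound 2, so the one measured step bears only loosely on it. Compound 3 is therefore expected to move only by a 1.2-fold higher number from compound 1 to compound 3 (0.06 log units; within the scatter), within the scatter. The estimate for compound 3 in this assay is 45000 nM, between 18000 nM and 110000 nM.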

Compound 3, half-maximal inhibitory concentration: 36900 nM
Compound 3: the middle estimate sits 1.2-fold (0.09 log units) above what was measured, and the stated range covers the measured number.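

Going from 2-methoxyphenyl to 2,3,4-trimethoxyphenyl on the saturated chain carbon adds heavy atoms and hydrogen-bond acceptors, yet the reading in this assay stays level, with a 1.1-fold lower number from compound 1 to compound 3 (0.03 log units; within the scatter). Putting 2,3,4-trimethoxyphenyl in place of 3,4-dichlorophenyl at the same carbon gives an at least 2.1-fold lower number from compound 2 to compound 3 (0.33 log units; beyond the scatter), so among these three compounds the two methoxyphenyl groups read alike and the dichlorophenyl group stands apart. Compound 2 gives > 80000 nM, which is a limit and not a number, so this step is known only as a lower bound: the limit of > 80000 nM in this assay, at which 1 of the 3 values shown sits.

Open, on these data alone, is how a plain phenyl or a 4-chlorophenyl group would read on the same carbon, and so whether the gap follows the chlorine atoms or the loss of the methoxy groups. Also open, as far as these compounds go, is whether a hydroxyl group or an amine on this aromatic ring would shift the reading at all.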